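The source may hold more compounds than are shown below. What is called first, only, known or untested is meant among the compounds shown, and "the series" means these compounds.

Compound 1 `O=C(O[C@H]1C[C@H](n2cc(F)c(=O)[nH]c2=O)O[C@@H]1COP(=O)(O)Oc1ccccc1)c1ccccc1` gives 800 nM in a functional assay on U-87MG ATCC cells for cytotoxicity against U-87 MG (Homo sapiens), read by MTT assay, with a stated time of 48 h (a higher number here means a weaker inhibitor, a lower number a stronger inhibitor), the lowest of the two numbers in hand. Compound 2 `CCCCCCCCCc1ccc(OP(=O)(O)OC[C@H]2O[C@@H](n3cc(F)c(=O)[nH]c3=O)C[C@@H]2OC(=O)c2ccccc2)cc1` gives 6730 nM in this assay, and the step of an 8.4-fold higher number from compound 1 to compound 2 (0.92 log units; beyond the scatter) is the only measured one in the series. Compound 3 `O=C(O[C@H]1C[C@H](n2cc(F)c(=O)[nH]c2=O)O[C@@H]1COP(=O)(O)Oc1cccnc1)c1ccccc1` differs from compound 1 by pyridin-3-yl in place of phenyl on an oxygen. For the measured compounds named here, no measured step bears on this kind of change; the nonyl step alters a different part of the structure and gives no guide here. For compound 3 a step within the scatter, in either direction, is expected, a 1.3-fold higher number from compound 1 to compound 3 (0.10 log units; within the scatter). Compound 3 is therefore estimated at 1000 nM, within 400 nM to 2500 nM.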

Compound 3, half-maximal inhibitory concentration: 710 nM
For compound 3 the middle estimate is 1.4-fold (0.15 log units) above the measured one, and the stated range covers the measured number.
By their numbers in this assay, from the lowest: compounds 3 and 1 (each within the scatter of the next); then compound 2.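

On the oxygen whose other neighbour is phosphorus, pyridin-3-yl in place of phenyl gives a 1.1-fold lower number from compound 1 to compound 3 (0.05 log units; within the scatter) in this assay. This aryl group can therefore take a ring nitrogen and a hydrogen-bond acceptor without a change in the read-out beyond the scatter, whereas the nonyl step from the same parent goes beyond it. No evidence on hand gives a reason for this result.

On these data alone, whether pyridin-4-yl would behave the same remains open. So does the effect of an amine or a carboxylic acid on the phenyl ring, or of a chain shorter than nonyl.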